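The compounds below may be only part of what the source reports. "The series", "measured", "known", "first", "only" and "open" are said of these compounds alone.

Measured compounds, with their solubility in a physicochemical assay for solubility, read by HPLC; a lower number here means a less soluble compound, a higher number a more soluble compound:
compound 1 `O=C(CC1CCCCC1)N1CCN(c2nc(=O)c3cc(C(F)(F)F)cc([N+](=O)[O-])c3s2)CC1` gives 0.12 ug/mL
compound 2 `CSCC(=O)N1CCN(c2nc(=O)c3cc(C(F)(F)F)cc([N+](=O)[O-])c3s2)CC1` gives 15.2 ug/mL
compound 3 `Cc1ccc(C(=O)N2CCN(c3nc(=O)c4cc(C(F)(F)F)cc([N+](=O)[O-])c4s3)CC2)cc1` gives 6.7 ug/mL

Compound 3 stands second highest of the three numbers in this assay. Its nearest neighbour is compound 2, separated by the step of a 2.3-fold lower number from compound 2 to compound 3 (0.36 log units; beyond the scatter); its furthest is compound 1, separated by the step of a 56-fold higher number from compound 1 to compound 3 (1.75 log units; beyond the scatter). Both steps lie beyond the scatter. The remaining step, a 130-fold higher number from compound 1 to compound 2 (2.10 log units; beyond the scatter), is the largest in the set.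

Compound 4 `O=C(c1ccccc1Cl)N1CCN(c2nc(=O)c3cc(C(F)(F)F)cc([N+](=O)[O-])c3s2)CC1` differs from compound 3 in one place: 2-chlorophenyl in place of 4-methylphenyl on a carbonyl carbon. For the measured compounds named here, none of the measured steps changes a substituent on an aromatic ring that is bound to the carbonyl carbon. Going by the values given here, the only step that involves the 4-methylphenyl group at all, a 2.3-fold lower number from compound 2 to compound 3 (0.36 log units; beyond the scatter), exchanges the whole acyl group and was modest; the two large steps likewise exchange the whole acyl group. There is thus no direct measure of swapping one substituted phenyl for another on this carbonyl carbon. The step from compound 3 to compound 4 is therefore expected to be small, a 1.0-fold higher number from compound 3 to compound 4 (0.02 log units; within the scatter), with no change beyond the scatter in either direction. Compound 4 is expected to give 7 ug/mL in this assay, within a range from 2.5 ug/mL to 20 ug/mL.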

Compound 4, solubility: 8.18 ug/mL
Beside the measured number, compound 4's estimate is 1.2-fold (0.07 log units) below it, within the range that was stated.
By their numbers in this assay, from the lowest: compound 1; then compounds 3, 4 and 2 (each within the scatter of the next, the first and the last beyond it).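

In this assay, the exchange of one substituted phenyl for another on this carbonyl carbon now has a direct reading: a 1.2-fold higher number from compound 3 to compound 4 (0.09 log units; within the scatter). That step lies within the scatter, so 4-methylphenyl and 2-chlorophenyl cannot be told apart at this position, even though they differ in the atoms they carry and compound 4 has its substituent named at a different ring position.

The whole-acyl exchange a 1.9-fold lower number from compound 2 to compound 4 (0.27 log units; within the scatter) also lies within the scatter, whereas a 68-fold higher number from compound 1 to compound 4 (1.83 log units; beyond the scatter) is large and beyond it, so compound 1, with its cyclohexylmethyl group, remains apart from compounds 2, 3 and 4 in this set. Nothing available explains why the number holds across the phenyl exchange or why compound 1 stands apart.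

The compounds shown cover only two substituents on a phenyl ring at this carbonyl carbon, so it remains open whether the flat reading would extend to a phenyl ring carrying an amine or a carboxylic acid. From the compounds shown here alone, it also remains open how a longer chain between the carbonyl and the phenyl ring would read, and whether the low number of compound 1 goes with the cyclohexyl ring or with its methylene link.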